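The source may report more compounds than this note shows. Statements on the series, on what has been measured and on what is new or still open speak of the compounds shown alone.

Measured in a toxicity assay on L02 cells (Homo sapiens) for cytotoxicity, read by MTT assay, with a stated time of 72 h; on this read-out lower numbers stand for stronger inhibition and higher numbers for weaker inhibition:
- compound 1 `O=C1c2c[n+]([O-])c3ccccc3c2C(=O)c2c1c1ccccc1n2Cc1cn(C[C@H](O)CO)nn1`: 1130 nM
- compound 2 `O=C1c2c[n+]([O-])c3ccccc3c2C(=O)c2c1c1ccccc1n2CCN1CCCC1`: 930 nM
- compound 3 `O=C1c2c[n+]([O-])c3ccccc3c2C(=O)c2c1c1ccccc1n2CCCCN1CCNCC1`: 1380 nM

In this assay, compound 1 sits in a tight group with the other two, and neither of its steps separates it from them: a 1.2-fold lower number from compound 1 to compound 2 (0.08 log units; within the scatter), and a 1.2-fold higher number from compound 1 to compound 3 (0.09 log units; within the scatter). The remaining pair behaves alike, with a 1.5-fold higher number from compound 2 to compound 3 (0.17 log units; within the scatter).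

The next compound to be tested is compound 4 `CC1(C)OC[C@H](Cn2cc(Cn3c4c(c5ccccc53)C(=O)c3c[n+]([O-])c5ccccc5c3C4=O)nn2)O1`, which keeps the shared core and the triazole of compound 1 but alters the end of the side chain: 2,2-dimethyl-1,3-dioxolan-4-yl in place of 1,2-dihydroxyethyl on a saturated chain carbon bound to an aromatic nitrogen. Cut one bond further out, this reads as 2,3-dihydroxypropyl to (2,2-dimethyl-1,3-dioxolan-4-yl)methyl.

Within the data shown here, no measured step makes this exact change, so the evidence is indirect. The closest guides are the two steps from compound 1, which replace the triazole-bearing group as a whole and are larger edits than this one, yet both stay within the scatter. On that basis, no shift beyond the scatter is expected, and no firm direction can be argued from these three compounds. The expected change is a 1.1-fold lower number from compound 1 to compound 4 (0.05 log units; within the scatter). Compound 4 is estimated at 1000 nM, with an expected range from 450 nM to 2200 nM.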

Compound 4, half-maximal inhibitory concentration: 470 nM
Beside the measured number, compound 4's estimate is 2.1-fold (0.33 log units) above it; measured number inside the range.
By their numbers in this assay, from the lowest: compounds 4, 2, 1 and 3 (each within the scatter of the next, the first and the last beyond it).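

In this assay, the end of the side chain proves to be a place where a change can register: the only listed step beyond the scatter is the modest one here (a 2.4-fold lower number from compound 1 to compound 4 (0.38 log units; beyond the scatter)). The earlier steps shown here from compound 1 replaced the whole triazole-bearing group and stayed within the scatter, whereas this one keeps the triazole and the shared core and alters only the group on the saturated chain carbon bound to an aromatic nitrogen. The 1,2-dihydroxyethyl group, with 2 hydrogen-bond donors, gives way to 2,2-dimethyl-1,3-dioxolan-4-yl, with 0 hydrogen-bond donors and one five-membered non-aromatic ring, while the count of 2 hydrogen-bond acceptors stays the same, and no measurement shown here explains the step.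

These compounds cannot separate the loss of the two hydroxyl groups from the gain of the ring and its two methyl groups, a question that an open-chain analogue with two methoxy groups could address. As far as these compounds go, it also remains open whether a larger ketal, such as a cyclohexylidene ketal, or the opposite configuration at the stereocentre would give a similar number.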